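Swapping chloro for bromo on the shared core

A few compounds are considered here, and "the series" means these few. Any claim that something is new, unique, unknown or untested is made for them only; others in the source may bear on it.

For the measured compounds named here, in a physicochemical assay for pharmacokinetics, read by HPLC, in phosphate buffer, at pH 7.4 (on this read-out higher numbers stand for a longer-lived compound and lower numbers for a shorter-lived compound), three compounds sharing one core have numbers so far. Compound 1 `CCCC(CCC)C(=O)N(C)/N=N/c1ccc(C(=O)OCC)cc1` gives 34.1 h, compound 2 `CCCC(CCC)C(=O)N(C)/N=N/c1ccc(C(=O)OC)cc1` gives 31.4 h, and compound 3 `CCCC(CCC)C(=O)N(C)/N=N/c1ccc(Cl)cc1` gives 27.3 h. Compound 3 therefore stands within the scatter of both of the others, and the three numbers form a single group.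

The next compound is compound 4 `CCCC(CCC)C(=O)N(C)/N=N/c1ccc(Br)cc1`, which differs from compound 3 by one exchange: bromo in place of chloro on an aromatic carbon. This places bromo in place of chloro on an aromatic carbon, para to a large group. Going by the values given here, no measured step makes this exact exchange. The closest evidence comes from two other exchanges that end in chloro on an aromatic carbon: a 1.2-fold lower number from compound 1 to compound 3 (0.10 log units; within the scatter) with chloro in place of ethoxycarbonyl, and a 1.2-fold lower number from compound 2 to compound 3 (0.06 log units; within the scatter) with chloro in place of methoxycarbonyl. The remaining step, hydrogen in place of methyl on a saturated chain carbon, is a 1.1-fold lower number from compound 1 to compound 2 (0.04 log units; within the scatter). All three steps lie within the scatter, so no step beyond it is expected here, and no direction is favoured. The estimated step is a 1.0-fold lower number from compound 3 to compound 4 (0.00 log units; within the scatter), which is expected to stay within the scatter. Compound 4 is estimated at 27 h, with an expected range from 19 h to 38 h.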

Compound 4, half-life: 30.4 h
Estimate against measurement, compound 4: 1.1-fold (0.05 log units) below; low and high end bracket the measured number.
By their numbers in this assay, from the lowest: compounds 3, 4, 2 and 1 (each within the scatter of the next).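

In this assay, for the compounds shown here, this is the first exchange at this place, on an aromatic carbon para to a large group, in which one halogen replaces another, and bromo in place of chloro gives no step beyond the scatter (a 1.1-fold higher number from compound 3 to compound 4 (0.05 log units; within the scatter)). Set against the two carbonyl-bearing groups, bromo also stays within the scatter, both in place of methoxycarbonyl (a 1.0-fold lower number from compound 2 to compound 4 (0.01 log units; within the scatter)) and in place of ethoxycarbonyl (a 1.1-fold lower number from compound 1 to compound 4 (0.05 log units; within the scatter)), so all four groups shown at this place, chloro, bromo, methoxycarbonyl and ethoxycarbonyl, give half-lives that form one group. No further measurement on these compounds accounts for this lack of separation.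

From the compounds shown here alone, all four groups at this place are halogens or esters, so it remains open whether an amine or a carboxylic acid there would stay within the same group. The rest of the shared core is the same in all four compounds, which leaves open what a hydroxyl group or a longer chain elsewhere on the core would do to the half-life.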